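N-Methylation of a Ring Amine Across Two Related Cores

The source may report more compounds than this note shows. Statements on the series, on what has been measured and on what is new or still open speak of the compounds shown alone.

Measured in a functional assay on HCT-116 cells (Homo sapiens) for antiproliferative activity; a higher number here means a weaker inhibitor, a lower number a stronger inhibitor:
compound 1, `Cc1c2c(n3c1CCCN[C@@H](C)[C@H](C)Nc1cc-3ccc1C(N)=O)CC(C)(C)CC2=O`, gives 29 nM
compound 2, `Cc1c2c(n3c1CCNC[C@@H](C)[C@H](C)Nc1cc-3ccc1C(N)=O)CC(C)(C)CC2=O`, gives 24 nM
compound 3, `Cc1c2c(n3c1CCCN(C)[C@@H](C)[C@H](C)Nc1cc-3ccc1C(N)=O)CC(C)(C)CC2=O`, gives 51 nM

Compounds 1 and 2 share the same atoms joined differently; the difference between the two cores is not broken down here, and their two values lie within the scatter of each other. Compound 3 arises from compound 1 by methyl in place of hydrogen on an amine nitrogen in a ring, a step of a 1.8-fold higher number from compound 1 to compound 3 (0.25 log units; within the scatter). Compound 4, `Cc1c2c(n3c1CCN(C)C[C@@H](C)[C@H](C)Nc1cc-3ccc1C(N)=O)CC(C)(C)CC2=O`, not yet measured, arises from compound 2 by methyl in place of hydrogen on an amine nitrogen in a ring. The place differs: in compound 1 the nitrogen sits next to the ring atom that bears a methyl group, in compound 2 two ring bonds from it, so this is the same kind of change rather than the same change. Resting on compound 2 at 24 nM and the step of compound 1 to compound 3, the expected step is a 1.8-fold higher number from compound 2 to compound 4 (0.25 log units; within the scatter). Compound 4 is estimated at 43 nM, between 20 nM and 95 nM.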

Compound 4, half-maximal inhibitory concentration: 27 nM
The estimate for compound 4 lay 1.6-fold (0.20 log units) above the measured number; the measured number falls inside the stated range.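

In this assay, methyl in place of hydrogen on an amine nitrogen in a ring gives a 1.1-fold higher number from compound 2 to compound 4 (0.05 log units; within the scatter), and this step can be set beside the earlier one: the same change on two cores in this assay, a 1.8-fold higher number (0.25 log units; within the scatter) from compound 1 to compound 3 and a 1.1-fold higher number (0.05 log units; within the scatter) from compound 2 to compound 4, 1.6-fold (0.19 log units) apart, within the scatter of two such steps. The change therefore carries between these two cores without a difference that can be told from the scatter, and neither step on its own can be told from it either. Two pairs do not make a rule for the series, and since the nitrogen sits in a different place in each pair, they cannot separate the effect of the core from that of the place.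

The compounds shown leave open how an ethyl or acetyl group on that same nitrogen would compare with methyl.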